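This account rests on a few compounds, and the source may have more. Where it says the series, first, only, none or still open, it means among the compounds named here.

Compounds measured so far:
compound 1, `Oc1cccc(-c2cc(-c3cccc(Cl)c3)nc(-c3ccco3)c2)c1`, 3570 nM
compound 2, `Oc1cccc(-c2cc(-c3ccccn3)nc(-c3ccccc3Cl)c2)c1`, "not determined" (no result reported)
compound 3, `Oc1cccc(-c2cc(-c3ccccc3)nc(-c3ccccc3Cl)c2)c1`, 2920 nM

The three compounds share one core and were tested in a functional assay on T47D cells (Homo sapiens) for cytotoxicity, read by CCK-8 assay and cell counting, with a stated time of 2 days; on this read-out higher numbers stand for weaker inhibition and lower numbers for stronger inhibition. Compound 3 gives 2920 nM and compound 1 gives 3570 nM, and the gap between these two numbers is within the scatter, so compound 3 stands level with compound 1 rather than apart from it. Compound 2 contributes no number, as its result in this assay was "not determined" (no result reported).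

Compound 4, `Oc1cccc(-c2cc(-c3ccco3)nc(-c3ccccc3Cl)c2)c1`, differs from compound 3 in one place: furan-2-yl in place of phenyl on an aromatic carbon. Compound 1 already carries furan-2-yl at the same kind of position and its value in this assay sits within the scatter of compound 3, so no step beyond the scatter is expected in either direction. Compound 4 is therefore estimated at 3300 nM, with a range from 1500 nM to 7500 nM, which means an expected step of a 1.1-fold higher number from compound 3 to compound 4 (0.05 log units; within the scatter).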

Compound 4, half-maximal inhibitory concentration: 2010 nM
Beside the measured number, compound 4's estimate is 1.6-fold (0.22 log units) above it; low and high end bracket the measured number.
By their numbers in this assay, from the lowest: compounds 4, 3 and 1 (each within the scatter of the next).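

In this assay, going by these compounds alone, the earlier compounds offered no comparison across a single change, and this pair supplies the first: with 2-chlorophenyl held in place, furan-2-yl in place of phenyl on the aromatic carbon next to the ring nitrogen gives a 1.5-fold lower number from compound 3 to compound 4 (0.16 log units; within the scatter). At this position, a five-membered aromatic ring with one oxygen therefore reads the same as the six-membered carbon ring, and with furan-2-yl held in place, 2-chlorophenyl in place of 3-chlorophenyl gives a 1.8-fold lower number from compound 1 to compound 4 (0.25 log units; within the scatter), so neither change moves the number beyond the scatter. No measurement here offers an explanation for either step.

The compounds shown leave open whether a non-aromatic group at this position, such as an amine, a carboxylic acid or a longer alkyl chain, would shift the number beyond the scatter. They also leave open what replacing the hydroxyl of the 3-hydroxyphenyl group with a methoxy group would do.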